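Swapping one halogenated phenyl for another on a shared core

The source may report more compounds than this note shows. Statements on the series, on what has been measured and on what is new or still open speak of the compounds shown alone.

Measured compounds:
Compound 1, `CCCCCCCCCCCCCCCCCCNC(=O)[C@H]1CSC(c2cccnc2)N1`, gives 10500 nM in a functional assay on RH7777 cells (Homo sapiens) for antiproliferative activity against RH7777 (Rattus norvegicus), read by sulforhodamine B assay; on this read-out higher numbers stand for weaker inhibition and lower numbers for stronger inhibition.
Compound 2, `CCCCCCCCCCCCCCCCCCNC(=O)[C@H]1CSC(c2ccc(Br)cc2)N1`, gives only a limit of the assay in this assay, namely > 20000 nM.

Compound 2 thus stands at the edge of what this assay reports, as the limit of > 20000 nM in this assay, at which 1 of the 2 values shown sits, records. Among the compounds with values here, the single measured step, an at least 1.9-fold higher number from compound 1 to compound 2 (0.27 log units; that floor lies within the scatter), has a floor that lies within the scatter, so compound 2 may sit close to compound 1 or far weaker; the data do not decide this.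

Compound 3, `CCCCCCCCCCCCCCCCCCNC(=O)[C@H]1CSC(c2c(Cl)cccc2Cl)N1`, differs from compound 2 in one place: 2,6-dichlorophenyl in place of 4-bromophenyl on a saturated ring carbon. Within the data shown here, no measured step covers an exchange of one halogenated phenyl for another on this saturated ring carbon. The step from the pyridine to the bromophenyl bears on it only loosely, because an at least 1.9-fold higher number from compound 1 to compound 2 (0.27 log units; that floor lies within the scatter) shows that a halogenated phenyl at this position gave no number at all, and compound 3 keeps a halogenated phenyl there.

Compound 3 is therefore expected to remain near the limit, with an estimated 25000 nM, ranging from 9000 nM to 70000 nM. The expected step is a step that the limit leaves unreadable from compound 2 to compound 3, essentially none beyond the scatter.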

Compound 3, half-maximal inhibitory concentration: > 20000 nM
Compound 3: no number, only a limit; the forecaster's own chance of this, stated with the estimate: 65%; the middle value is on the limit's open side.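

In this assay compound 3 gives > 20000 nM, which is a limit of the assay and not a number, so a second halogenated phenyl, this time 2,6-dichlorophenyl, also yields no number on this saturated ring carbon. The exchange of one halogenated phenyl for the other cannot be read, as both ends are limits, and the pyridin-3-yl exchange gives an at least 1.9-fold higher number from compound 1 to compound 3 (0.27 log units; that floor lies within the scatter), so this change, like the 4-bromophenyl one, may be a small shift or a large loss. Among the three groups shown at this position, only pyridin-3-yl gives a number, and the limit now describes most of the set: the limit of > 20000 nM in this assay, at which 2 of the 3 values shown sit.

On these data alone, how far either halogenated compound lies from compound 1 stays open, as does whether a phenyl carrying an amine or a carboxylic acid on this carbon would return a readable number. As far as these compounds go, the long chain on the amide is the same in all three compounds, so what a shorter chain would do to the read-out is also open.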